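Methoxy for Methyl on the Sulfonyl Aryl Ring

The compounds below may be only part of what the source reports. "The series", "measured", "known", "first", "only" and "open" are said of these compounds alone.

Three compounds share one core and differ only in the group on the sulfonyl sulfur. Compound 1 `CCCCS(=O)(=O)NNC(=O)[C@@H](NC(=O)c1cccc(Cn2ccnc2)c1)[C@@H](C)CC` carries a butyl group there. In an assay on HEK293 cells for displacement of a labelled ligand from Type-2 angiotensin II receptor (Homo sapiens) (a lower number here means a stronger inhibitor, a higher number a weaker inhibitor), compound 1 gives > 100000 nM, which is a limit of the assay rather than a number. Compound 2 `CC[C@H](C)[C@H](NC(=O)c1cccc(Cn2ccnc2)c1)C(=O)NNS(=O)(=O)c1ccccc1` carries a phenyl group, and in this assay compound 2 gives > 100000 nM, again a limit. Within the data shown here, compound 3 `CC[C@H](C)[C@H](NC(=O)c1cccc(Cn2ccnc2)c1)C(=O)NNS(=O)(=O)c1ccc(C)cc1` carries a 4-methylphenyl group, and in this assay compound 3 gives 29000 nM, the only number among the three. Of the measured steps, a step that the two limits leave unreadable from compound 1 to compound 2 cannot be read, while an at least 3.4-fold lower number from compound 1 to compound 3 (0.53 log units; beyond the scatter) and an at least 3.4-fold lower number from compound 2 to compound 3 (0.53 log units; beyond the scatter) are readable only as lower bounds because the limit of > 100000 nM in this assay, at which 2 of the 3 values shown sit, fixes their starting points. Compound 4 `CC[C@H](C)[C@H](NC(=O)c1cccc(Cn2ccnc2)c1)C(=O)NNS(=O)(=O)c1ccc(OC)cc1` differs from compound 3 by methoxy in place of methyl on an aromatic carbon. Among the measured compounds shown here, no measured step exchanges one small group for another on that ring, so the expectation rests on compound 3 alone, and the step of a 1.0-fold higher number from compound 3 to compound 4 (0.01 log units; within the scatter) is expected to stay within the scatter. Compound 4 is estimated at 30000 nM in this assay, with a range from 8000 nM to 100000 nM.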

Compound 4, inhibition constant: 9200 nM
Beside the measured number, compound 4's estimate is 3.3-fold (0.51 log units) above it, within the range that was stated.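

Methoxy in place of methyl on the aromatic ring gives a 3.2-fold lower number from compound 3 to compound 4 (0.50 log units; beyond the scatter) in this assay, the first step in this series read between two real numbers, so the group at this place para to a large group still changes the result once a value can be read. Against the other two compounds, the result is an at least 10-fold lower number from compound 2 to compound 4 (1.03 log units; beyond the scatter) and an at least 10-fold lower number from compound 1 to compound 4 (1.03 log units; beyond the scatter), and both steps are only lower bounds because their starting points are limits: the limit of > 100000 nM in this assay, at which 2 of the 4 values shown sit.

Compound 4 is the strongest of the four compounds.

From the compounds shown here alone, how a chlorine, an amine or a carboxylic acid at the same place would compare with methoxy stays open. Two groups at one place also cannot tell whether the oxygen itself or simply the added heavy atom goes with the step.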